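The source may report more compounds than this note shows. Statements on the series, on what has been measured and on what is new or still open speak of the compounds shown alone.

Three compounds share one core and were measured in a functional assay on Ehrlich cells (Mus musculus) for cytotoxicity, tested at 100 ug/mL; a lower number here means a weaker effect, a higher number a stronger effect of the compound at the concentration tested:

Compound 1 `COc1ccc(C2C(C#N)=C(N)N(c3cc(OC)c(OC)c(OC)c3)C3=C2C(=O)CC(C)(C)C3)cc1` gives 15%.
Compound 2 `COc1cc(N2C(N)=C(C#N)C(/C=C/c3ccccc3)C3=C2CC(C)(C)CC3=O)cc(OC)c1OC` gives 40%.
Compound 3 `COc1cc(N2C(N)=C(C#N)C(c3cccc([N+](=O)[O-])c3)C3=C2CC(C)(C)CC3=O)cc(OC)c1OC` gives 30%.

Compound 1 stands lowest of the three in this assay; the nearest is compound 3 a number 15 percentage points higher from compound 1 to compound 3 (beyond the scatter), the furthest compound 2 a number 25 percentage points higher from compound 1 to compound 2 (beyond the scatter). Compounds 2 and 3 sit close to each other a number 10 percentage points lower from compound 2 to compound 3 (within the scatter).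

Compound 4 `COc1ccccc1C1C(C#N)=C(N)N(c2cc(OC)c(OC)c(OC)c2)C2=C1C(=O)CC(C)(C)C2` is not yet measured. It is built from the same atoms as compound 1, joined differently: 2-methoxyphenyl in place of 4-methoxyphenyl on a saturated ring carbon.

For the measured compounds named here, no measured step swaps one methoxyphenyl for another, so the expectation rests on the two steps that replace the 4-methoxyphenyl group at the same saturated ring carbon, from compound 1 to compound 2 and from compound 1 to compound 3. Both raise the read-out modestly, beyond the scatter, with groups that differ far more from 4-methoxyphenyl than 2-methoxyphenyl does. A smaller change is therefore expected here: a modest rise, or possibly none beyond the scatter. The expected step is a number 10 percentage points higher from compound 1 to compound 4 (within the scatter). Compound 4 is estimated at 25%, with a range from 10% to 45%.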

Compound 4, a percentage reported as activity, at one concentration (the size of the read-out at that concentration, not a potency): 100%
Compound 4: middle estimate off by 75 percentage points, on the low side; the measured number lies above the stated range.
By their numbers in this assay, from the lowest: compound 1; then compounds 3 and 2 (each within the scatter of the next); then compound 4.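

In this assay, 2-methoxyphenyl in place of 4-methoxyphenyl on the saturated ring carbon gives a number 85 percentage points higher from compound 1 to compound 4 (beyond the scatter), so at this position the read-out depends strongly on where the methoxy group sits on the phenyl ring, even though the two groups hold the same atoms. The same group also stands well clear of the other two groups tested at this carbon, with a number 70 percentage points higher from compound 3 to compound 4 (beyond the scatter) and a number 60 percentage points higher from compound 2 to compound 4 (beyond the scatter), so the swaps to 3-nitrophenyl and 2-phenylethenyl gave no hint of how much this small rearrangement could matter. Nothing available here explains why the two methoxyphenyl groups behave so differently.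

As far as these compounds go, whether a 3-methoxyphenyl, 2-methylphenyl or 2-chlorophenyl group at this carbon would behave like 2-methoxyphenyl remains open, and with it whether the methoxy group itself matters or any group placed there would do the same. From the compounds shown here alone, the read-out comes from a single concentration, so the potency of compound 4 also remains open, as does whether its effect extends to other cell types.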